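Trimming a Pyridylmethyl Arm from a Piperazine Dithiocarbamate

The source may hold more compounds than are shown below. What is called first, only, known or untested is meant among the compounds shown, and "the series" means these compounds.

Measured compounds:
compound 1, `CN(C(=S)SCc1ccc(C(=O)Nc2ccccc2N)cc1)c1cccnc1`, 70.5%
compound 2, `Nc1ccccc1NC(=O)c1ccc(CSC(=S)N2CCCc3ccccc32)cc1`, 35.7%
compound 3, `Nc1ccccc1NC(=O)c1ccc(CSC(=S)N2CCN(Cc3ccncc3)CC2)cc1`, 72.9%

Compound 3 gives the highest of the three numbers in a functional assay on HeLa cells (Homo sapiens) for antiproliferative activity, read by CCK-8 assay, with a stated time of 72 h, tested at 8 uM (a higher number here means a stronger effect of the compound at the concentration tested, a lower number a weaker effect), but its gap to compound 1 is within the scatter, so the two cannot be ranked; compound 2 lies clearly lower than both. Among the compounds with values here, the one step computed so far, a number 34.8 percentage points lower from compound 1 to compound 2 (beyond the scatter), swaps the whole amine on the thiocarbonyl carbon and is large, but it changes a different part of the molecule.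

Compound 4, `CN1CCN(C(=S)SCc2ccc(C(=O)Nc3ccccc3N)cc2)CC1`, differs from compound 3 by hydrogen in place of pyridin-4-yl on a saturated chain carbon bound to an amine nitrogen in a ring. Within the data shown here, no measured pair reports this change on its own. Compounds 1 and 3 both carry a pyridine ring on the amine side and both sit near the top of the range, while compound 2, without one, sits far lower; that is only a hint, not a step.

Among the measured compounds shown here, because the one large step, a number 34.8 percentage points lower from compound 1 to compound 2 (beyond the scatter), shows that the amine side matters, a moderate loss is expected: a number 17.9 percentage points lower from compound 3 to compound 4 (beyond the scatter). Compound 4 is estimated at 55%, in the range 35% to 75%.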

Compound 4, a percentage reported as inhibition, at one concentration (the size of the read-out at that concentration, not a potency): 75.7%
Compound 4: the middle estimate sits 20.7 percentage points below what was measured, outside the stated range (above it).
By their numbers in this assay, from the lowest: compound 2; then compounds 1, 3 and 4 (each within the scatter of the next).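

In this assay, cutting the (pyridin-4-yl)methyl arm back to methyl gives a number 2.8 percentage points higher from compound 3 to compound 4 (within the scatter) and so removes a whole aromatic ring at this place without a change that can be told from scatter. This shows that the pyridin-4-yl group is not required for the read-out at the tested concentration, at least on this piperazine. The earlier hint linking a pyridine ring to the higher numbers also fails: compound 4 has no pyridine ring, yet replacing the amine of compound 1 gives a number 5.2 percentage points higher from compound 1 to compound 4 (within the scatter) and replacing the amine of compound 2 gives a number 40 percentage points higher from compound 2 to compound 4 (beyond the scatter) so the low number of compound 2 cannot be read as the lack of such a ring.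

On these data alone, it remains open whether a hydrogen, an ethyl group, a longer chain or a carboxylic acid on that piperazine nitrogen would hold the read-out, and a single-concentration read-out cannot separate compounds that all sit this close together. Nothing available here speaks to the reason for these results.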